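A larger branch on a hydroxycarbamoyl chain

A few compounds are considered here, and "the series" means these few. Any claim that something is new, unique, unknown or untested is made for them only; others in the source may bear on it.

Of the compounds shown here, two on a shared core have been measured in a functional assay on HEL cells (Homo sapiens) for inhibition, read by MTT assay, with a stated time of 48 h (on this read-out lower numbers stand for stronger inhibition and higher numbers for weaker inhibition), so far. Compound 1 (`O=C(CCCCOc1no[n+]([O-])c1S(=O)(=O)c1ccccc1)NO`) gives 1030 nM there, while compound 2 (`CC(C)(COc1no[n+]([O-])c1S(=O)(=O)c1ccccc1)C(=O)NO`) gives 5010 nM and is the weaker of the two.

Compound 3 (`CCCC(C)(COc1no[n+]([O-])c1S(=O)(=O)c1ccccc1)C(=O)NO`) departs from compound 2 by one change (ethyl in place of hydrogen on a saturated chain carbon, two bonds along the chain from a carbonyl carbon): ethyl in place of hydrogen on a saturated chain carbon, two bonds along the chain from a carbonyl carbon. Cut one bond further out, the same difference reads methyl to propyl.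

Among the measured compounds shown here, only one measured step bears on this, and only indirectly. Replacing 3-(hydroxycarbamoyl)propyl with 1-(hydroxycarbamoyl)-1-methylethyl gave a 4.9-fold higher number from compound 1 to compound 2 (0.69 log units; beyond the scatter) in this assay and was modest but beyond the scatter. For the measured compounds named here, that step altered the whole chain, so no measured pair shows what enlarging the branch alone does. The expectation therefore stays close to compound 2 at 5010 nM and allows for movement either way. The estimated change is a 1.3-fold lower number from compound 2 to compound 3 (0.10 log units; within the scatter) and is expected to stay within the scatter. Compound 3 is estimated at 4000 nM (expected range 1500 nM to 11000 nM).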

Compound 3, half-maximal inhibitory concentration: 71500 nM
Compound 3: the middle estimate sits 18-fold (1.25 log units) below what was measured, and the stated range ends below it.
By their numbers in this assay, from the lowest: compound 1; then compound 2; then compound 3.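

In this assay, ethyl in place of hydrogen on a saturated chain carbon, two bonds along the chain from a carbonyl carbon, gave a 14-fold higher number from compound 2 to compound 3 (1.15 log units; beyond the scatter) and so counts as a large step. The earlier step, a 4.9-fold higher number from compound 1 to compound 2 (0.69 log units; beyond the scatter), altered the whole chain and could not separate the effect of the branch from that of the other differences. This new pair isolates a single place, and it shows that on this read-out the number at this carbon responds strongly to a change of only this size, read one bond further out as methyl to propyl, and that the higher number goes with the larger group in this one pair. Nothing available accounts for the size of this step.

The compounds shown leave open whether the number climbs gradually or abruptly as the group at this carbon grows, since one step cannot separate the two, and an ethyl group in place of that methyl or propyl would fall between them. They also leave open whether the higher number depends on a plain carbon chain at this place, as a hydroxymethyl group, an amine or a cyclopropyl ring there could show.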